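A few compounds are considered here, and "the series" means these few. Any claim that something is new, unique, unknown or untested is made for them only; others in the source may bear on it.

In a functional assay on BT-549 cells (Homo sapiens) for cytotoxicity, read by MTT assay, with a stated time of 48 h; on this read-out lower numbers stand for stronger inhibition and higher numbers for weaker inhibition:
Compound 1 `COc1cc(/C=C2\C(=O)Nc3ccc(Cl)cc32)ccc1OCCCN1CC(C)OC(C)C1`: 2770 nM
Compound 2 `COc1cc(/C=C2\C(=O)Nc3ccc(C)cc32)ccc1OCCCN1CC(C)OC(C)C1`: > 20000 nM (a limit)
Compound 3 `COc1cc(/C=C2\C(=O)Nc3ccccc32)ccc1OCCCN1CCN(c2ncccc2C(F)(F)F)CC1`: > 20000 nM (a limit)

Among the measured compounds shown here, compound 1 holds the only actual number, and the other two results are limits, as the limit of > 20000 nM in this assay, at which 2 of the 3 values shown sit, shows. The next compound to be tested is compound 4 `COc1cc(/C=C2\C(=O)Nc3ccc(Cl)cc32)ccc1OCCCN1CCN(C)CC1`, which keeps the core of compound 1 and its chloro group. The change is 4-methylpiperazin-1-yl in place of 2,6-dimethylmorpholin-4-yl on a saturated chain carbon, three bonds along the chain from an oxygen on an aromatic ring, with 4-methylpiperazin-1-yl in place of 2,6-dimethylmorpholin-4-yl on a saturated chain carbon.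

For the measured compounds named here, only one measured step exists, an at least 7.2-fold higher number from compound 1 to compound 2 (0.85 log units; beyond the scatter), and it concerns methyl in place of chloro on an aromatic carbon, not the group that changes here. Going by the values given here, no measured step isolates a change of this group, so the evidence on its effect is thin. With the chloro group retained, compound 4 is expected to stay near compound 1 at 2770 nM.

The expected change is a 1.3-fold higher number from compound 1 to compound 4 (0.10 log units; within the scatter), which would not go beyond the scatter. For compound 4 the estimate is 3500 nM, with an expected range from 1000 nM to 12000 nM.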

Compound 4, half-maximal inhibitory concentration: 2170 nM
For compound 4 the middle estimate is 1.6-fold (0.21 log units) above the measured one; measured number inside the range.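

In this assay, among the compounds shown here, the exchange of 2,6-dimethylmorpholin-4-yl for 4-methylpiperazin-1-yl on the saturated chain carbon is the first measured change at this position, and it gives a 1.3-fold lower number from compound 1 to compound 4 (0.11 log units; within the scatter). For the compounds shown here, with the chloro group retained, this position therefore accepts either of these two rings without a change beyond the scatter, which the earlier compounds could not show. Compound 4 also adds a second actual number to the series, while the other two results remain limits: the limit of > 20000 nM in this assay, at which 2 of the 4 values shown sit.

The compounds shown leave open whether an open-chain amine such as diethylamino, or a longer chain between the oxygen and the ring, would read the same. They also leave open whether 4-methylpiperazin-1-yl would give an actual number with methyl in place of chloro.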